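This account rests on a few compounds, and the source may have more. Where it says the series, first, only, none or still open, it means among the compounds named here.

Compound 1 `NC(=O)c1c(NC(=O)c2ccccc2Br)sc2c1CCN(C(=S)Nc1ccccc1Cl)C2` is the starting point of this series. In a functional assay on HeLa cells (Homo sapiens) for antiproliferative activity, with a stated time of 24 h (a lower number here means a stronger inhibitor, a higher number a weaker inhibitor), compound 1 gives 46900 nM. Compound 2 `Cc1ccccc1C(=O)Nc1sc2c(c1C(N)=O)CCN(C(=S)Nc1ccccc1Cl)C2` carries a methyl in place of the bromo on an aromatic carbon, and in this assay compound 2 gives 35300 nM; the step of a 1.3-fold lower number from compound 1 to compound 2 (0.12 log units; within the scatter) stays within the scatter. Among the two measured compounds, compound 2 has the lower number, but its only neighbour, compound 1, sits within the scatter of it, so the two cannot be ranked.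

Compound 3 `COc1ccccc1C(=O)Nc1sc2c(c1C(N)=O)CCN(C(=S)Nc1ccccc1Cl)C2` differs from compound 2 by one change: methoxy in place of methyl on an aromatic carbon. Among the measured compounds shown here, the only measured step at this site, a 1.3-fold lower number from compound 1 to compound 2 (0.12 log units; within the scatter), was within the scatter, and nothing else bears on a methoxy at this place. No step beyond the scatter is therefore expected; the step of a 1.0-fold lower number from compound 2 to compound 3 (0.00 log units; within the scatter) is an estimate. For compound 3 in this assay the expected value is 35000 nM, with a range from 14000 nM to 90000 nM.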

Compound 3, half-maximal inhibitory concentration: > 50000 nM
Compound 3: a limit, no number; the forecaster's own chance of this, stated with the estimate: 10%; at least 1.4-fold (0.15 log units) between middle value and limit.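

In this assay compound 3 gives > 50000 nM, which is a limit and not a number. From the compounds shown here alone, the new steps, an at least 1.4-fold higher number from compound 2 to compound 3 (0.15 log units; that floor lies within the scatter) and an at least 1.0-fold higher number from compound 1 to compound 3 (0.02 log units; that floor lies within the scatter), show no change beyond the scatter at this aromatic carbon, ortho to a large group, but they are floors, so the true size of either step remains unknown. Unlike bromo and methyl, methoxy at this position gives a reading that reaches the limit of the assay: the limit of > 50000 nM in this assay, at which 1 of the 3 values shown sits.

Going by these compounds, how far compound 3 lies past that limit stays open. Also open, on these data alone, is how an amine, a carboxylic acid or a longer chain such as ethoxy at this carbon would read in this assay, and whether any of them would give a step beyond the scatter from compound 2.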